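The source may report more compounds than this note shows. Statements on the series, on what has been measured and on what is new or still open speak of the compounds shown alone.

Of the compounds shown here, two have been measured in a functional assay on IMR-90 cells for antagonist activity at B1 bradykinin receptor (Homo sapiens), read by calcium flux; on this read-out higher numbers stand for weaker inhibition and lower numbers for stronger inhibition. Compound 1, `Cc1nc(-c2c(F)cc(Cl)cc2-c2ccc(CNC(=O)N(C)O)c(F)c2)no1`, gives 32 nM in this assay. Compound 2, `CN(O)C(=O)NCc1ncc(-c2cc(Cl)cc(F)c2-c2nnn(C)n2)cc1F`, gives 17 nM in this assay. Going by the values given here, the two numbers lie within the usual scatter of repeated measurements of each other, so compound 2 cannot be called stronger or weaker than compound 1; it simply stands at the same level as the only other compound measured.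

Compound 3, `Cn1nnc(-c2c(F)cc(Cl)cc2-c2cnc(CNC(=O)N(O)C3CCCCC3)c(F)c2)n1`, is not yet measured. It differs from compound 2 in one place: cyclohexyl in place of methyl on an amide-type nitrogen. Among the compounds with values here, no measured pair in this set shows the effect of such a change, so the only anchor is compound 2 itself, which gives 17 nM. The step is therefore expected to be small, with no clear direction, and the step from compound 2 to compound 3 is estimated at a 1.8-fold higher number from compound 2 to compound 3 (0.25 log units; within the scatter). Compound 3 is expected to give about 30 nM in this assay, within a range from 6 nM to 150 nM.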

Compound 3, half-maximal inhibitory concentration: 3.9 nM
For compound 3 the middle estimate is 7.7-fold (0.89 log units) above the measured one; the whole stated range lies above it.
By their numbers in this assay, from the lowest: compound 3; then compounds 2 and 1 (each within the scatter of the next).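

Going by these compounds alone, on the amide-type nitrogen that also carries the oxygen, putting cyclohexyl in place of methyl gives a 4.4-fold lower number from compound 2 to compound 3 (0.64 log units; beyond the scatter) in this assay, the first step in this set that lies beyond the scatter. This shows that the nitrogen can carry a ring of six carbons, where compound 2 has a single carbon, and that here the larger group goes with stronger inhibition rather than a loss of it. No measurement at hand explains this gain, so the step stands as an observation only.

At this nitrogen the compounds shown hold only methyl and cyclohexyl, so it remains open whether a smaller ring such as cyclopropyl, an open chain such as n-butyl, a flat phenyl ring or a chain ending in an amine would go the same way. On these data alone, it also remains open whether cyclohexyl would bring a similar gain on the core of compound 1, which carries methyl at this nitrogen too.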